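This account rests on a few compounds, and the source may have more. Where it says the series, first, only, none or still open, it means among the compounds named here.

For the measured compounds named here, in a functional assay on HeLa cells (Homo sapiens) for antiproliferative activity, read by cell counting, with a stated time of 3 days (on this read-out higher numbers stand for weaker inhibition and lower numbers for stronger inhibition), compound 1 `COc1ccc(Oc2ccccc2NC(C)=C2C(=O)CC(c3ccccc3)CC2=O)cc1OC` gives 54 nM and compound 2 `COc1cc(Oc2ccccc2NC(C)=C2C(=O)CC(c3ccccc3)CC2=O)ccc1N` gives 33 nM, so compound 2 stands within the scatter of the only other measured compound. Compound 3 `CCOc1ccccc1NC(C)=C1C(=O)CC(c2ccccc2)CC1=O` departs from compound 2 far more than these two differ from each other: ethyl in place of 4-amino-3-methoxyphenyl on an oxygen on an aromatic ring. Going by the values given here, the one measured step, a 1.6-fold lower number from compound 1 to compound 2 (0.21 log units; within the scatter), is amino in place of methoxy on an aromatic carbon. It bears on the new change only weakly, as it alters a group on the aromatic ring and leaves that ring in place. Among the compounds with values here, no measured compound lacks that ring, so the data offer no direct guide, and the range must stay wide. A clear move toward weaker inhibition, well beyond the scatter, is nevertheless expected, and the estimated step is a 27-fold higher number from compound 2 to compound 3 (1.44 log units; beyond the scatter). Compound 3 is expected at 900 nM, with an estimated range from 150 nM to 5000 nM.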

Compound 3, half-maximal inhibitory concentration: 180 nM
Compound 3: the middle estimate sits 5.0-fold (0.70 log units) above what was measured, and the stated range covers the measured number.
By their numbers in this assay, from the lowest: compounds 2 and 1 (each within the scatter of the next); then compound 3.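

Taking the substituted phenyl ring off the oxygen weakens inhibition in this assay only modestly, whether ethyl replaces 4-amino-3-methoxyphenyl (a 5.5-fold higher number from compound 2 to compound 3 (0.74 log units; beyond the scatter)) or 3,4-dimethoxyphenyl (a 3.3-fold higher number from compound 1 to compound 3 (0.52 log units; beyond the scatter)). Both earlier compounds carry that ring, so they could not show what compound 3 (180 nM) now shows: the ring adds to inhibition at this position, but inhibition in the nanomolar range persists without it. Nothing measured here bears on the reason for this loss.

From the compounds shown here alone, it remains open whether a longer chain such as butyl, or a chain ending in an amine such as 2-aminoethyl, would recover the difference on this oxygen. Going by these compounds, it is equally open whether an unsubstituted phenyl would match compound 1 and compound 2 or fall closer to compound 3.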